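Removal of the aryl chloro in a cinnamamide series

A few compounds are considered here, and "the series" means these few. Any claim that something is new, unique, unknown or untested is made for them only; others in the source may bear on it.

Measured so far:
compound 1, `CCCc1cc(N)c2cc(NC(=O)/C=C/c3ccc(C(C)(C)C)cc3)ccc2n1`, 22 nM
compound 2, `CCCc1cc(N)c2cc(NC(=O)/C=C/c3ccc(Cl)cc3)ccc2n1`, 6 nM

In an assay on isolated protein for displacement of a labelled ligand from melanin-concentrating hormone receptor 1 (Homo sapiens) (on this read-out higher numbers stand for weaker inhibition and lower numbers for stronger inhibition), compound 2 gives the lower of the two numbers recorded; the nearest, compound 1, gives 22 nM, a gap that is beyond the usual scatter. For the measured compounds named here, the single measured step, a 3.7-fold lower number from compound 1 to compound 2 (0.56 log units; beyond the scatter), shows that the group on the far aromatic ring of the cinnamamide matters on this read-out.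

The next compound, compound 3, is `CCCc1cc(N)c2cc(NC(=O)/C=C/c3ccccc3)ccc2n1`. Relative to compound 2 the change is hydrogen in place of chloro on an aromatic carbon. Going by the values given here, no measured step removes a group from this ring outright; the one step at hand exchanges two groups and is modest in size. As far as these compounds go, with nothing to indicate the direction of a loss of the chloro, the step of a 2.5-fold higher number from compound 2 to compound 3 (0.40 log units; beyond the scatter) is expected to be modest and towards a higher number, on the grounds that the unsubstituted ring is untested and the measured exchange moved the number by a 3.7-fold lower number from compound 1 to compound 2 (0.56 log units; beyond the scatter). Compound 3 is therefore estimated at 15 nM, with a range from 5 nM to 45 nM in this assay.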

Compound 3, half-maximal inhibitory concentration: 1000 nM
For compound 3 the middle estimate is 67-fold (1.82 log units) below the measured one, and the stated range ends below it.
By their numbers in this assay, from the lowest: compound 2; then compound 1; then compound 3.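

In this assay, the step of a 170-fold higher number from compound 2 to compound 3 (2.22 log units; beyond the scatter) shows that the 4-chlorophenyl to phenyl change is far larger than the exchange of one substituent for another had suggested. The step of a 45-fold higher number from compound 1 to compound 3 (1.66 log units; beyond the scatter) points the same way: across these three compounds, with no exception among them, either group on this aromatic carbon gives a much lower number than hydrogen, and the difference between chloro and tert-butyl is small beside the difference between either of them and hydrogen. No measurement at hand accounts for this loss.

The compounds shown leave open whether the low numbers depend on chloro and tert-butyl in particular or extend to other groups on this carbon, such as fluoro, methoxy, an amine or a carboxylic acid. They also leave open whether the same dependence on this substituent persists when the rest of the molecule changes, for example with a longer chain on the shared core.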